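Swapping the aryl group on the saturated ring carbon

The source may hold more compounds than are shown below. What is called first, only, known or untested is meant among the compounds shown, and "the series" means these compounds.

Among the measured compounds shown here, in a functional assay on PC-3 cells (Homo sapiens) for cytotoxicity, read by WST assay, with a stated time of 72 h (on this read-out higher numbers stand for weaker inhibition and lower numbers for stronger inhibition), compound 1 `O=C1Nc2c(ccc(F)c2F)C1(c1ccccc1)c1ccc(O)cc1` gives 8.9 nM and compound 2 `O=C1Nc2c(ccc(F)c2F)C1(c1ccc(O)cc1)c1ccc(F)c(F)c1` gives 19 nM, the highest of the two numbers so far. Compound 3 `O=C1Nc2c(ccc(F)c2F)C1(c1ccc(O)cc1)c1cccnc1` follows from compound 2 by one change, pyridin-3-yl in place of 3,4-difluorophenyl on a saturated ring carbon. For the measured compounds named here, only one measured step bears on this, the replacement of phenyl by 3,4-difluorophenyl on that same carbon, a 2.1-fold higher number from compound 1 to compound 2 (0.33 log units; beyond the scatter). That step is modest but beyond the scatter. Going by the values given here, no measured compound carries pyridin-3-yl, so the direction rests on little evidence and the range stays wide. The expected change is a 1.6-fold higher number from compound 2 to compound 3 (0.20 log units; within the scatter), a modest step toward a higher number in this assay. Compound 3 is estimated at 30 nM, with an expected range of 10 nM to 100 nM.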

Compound 3, half-maximal inhibitory concentration: > 1000 nM
Compound 3: no number, only a limit (the forecaster's own chance of this, stated with the estimate: 3%); middle value at least 33-fold (1.52 log units) away from the limit.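

Pyridin-3-yl on the saturated ring carbon gives an at least 52-fold higher number from compound 2 to compound 3 (1.72 log units; beyond the scatter), and against the unsubstituted ring it gives an at least 110-fold higher number from compound 1 to compound 3 (2.05 log units; beyond the scatter). The second step involves no fluorine, so in this assay a change from phenyl to pyridin-3-yl alone is enough for a large step, whereas the earlier swap between two rings of carbon only stayed modest. Compound 3 has a limit of the assay and not a number, so both steps give only a minimum size: the limit of > 1000 nM in this assay, at which 1 of the 3 values shown sits.

On these data alone, whether this large step belongs to pyridin-3-yl alone stays open, since a pyridin-4-yl, a thiophene ring or a pyridin-3-yl carrying fluorine could behave differently. Also open, as far as these compounds go, is whether a small amine or methoxy group on the pyridine ring would bring the number back toward those of compound 1 and compound 2.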